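The compounds below may be only part of what the source reports. "The series", "measured", "known", "first", "only" and "open" are said of these compounds alone.

Measured compounds:
Compound 1 `CNc1nc(NCC(C)(C)C)cc(-c2ccccn2)n1` gives 73 nM in a functional assay on HEK293 cells for agonist activity at G-protein coupled receptor 39 (Homo sapiens), read by inositol phosphate accumulation; on this read-out higher numbers stand for an effect only at larger amounts of compound and lower numbers for an effect already at smaller amounts.
Compound 2 `CNc1nc(NCc2ccc(Cl)cc2Cl)cc(-c2ccccn2)n1` gives 0.8 nM in this assay.
Compound 3 `CNc1nc(NCc2ccc(Cl)cc2)cc(-c2ccccn2)n1` gives 15 nM in this assay.

Compound 3 stands second highest of the three numbers in this assay; its nearest neighbour is compound 1, with a 4.9-fold lower number from compound 1 to compound 3 (0.69 log units; beyond the scatter), and its furthest is compound 2, with a 19-fold higher number from compound 2 to compound 3 (1.27 log units; beyond the scatter). The unmeasured compound 4 `CNc1nc(NCC2CCCCC2)cc(-c2ccccn2)n1` differs from compound 3 in one place: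

cyclohexyl in place of 4-chlorophenyl on a saturated chain carbon bound to a nitrogen on an aromatic ring

Going by the values given here, two measured steps bear on this change, since both alter the same group on a saturated chain carbon bound to a nitrogen on an aromatic ring: a 4.9-fold lower number from compound 1 to compound 3 (0.69 log units; beyond the scatter) and a 91-fold lower number from compound 1 to compound 2 (1.96 log units; beyond the scatter). The step from compound 1 to compound 3 shows that a 4-chlorophenyl in that place gives a modestly lower number than tert-butyl, and cyclohexyl resembles tert-butyl in being a non-aromatic carbon group without chlorine. Compound 4 is therefore expected to give a modestly higher number than compound 3, estimated as a 3.0-fold higher number from compound 3 to compound 4 (0.48 log units; beyond the scatter), landing near compound 1. Compound 4 is estimated at 45 nM, within a range of 12 nM to 160 nM.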

Compound 4, half-maximal effective concentration: 11 nM
The estimate for compound 4 lay 4.1-fold (0.61 log units) above the measured number; the measured number lies below the stated range.
By their numbers in this assay, from the lowest: compound 2; then compounds 4 and 3 (each within the scatter of the next); then compound 1.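

In this assay, replacing the aromatic ring with a saturated one gives a 1.4-fold lower number from compound 3 to compound 4 (0.13 log units; within the scatter), so on a saturated chain carbon bound to a nitrogen on an aromatic ring, neither aromaticity nor chlorine is needed to reach the level of compound 3. Cyclohexyl also separates from tert-butyl, with a 6.6-fold lower number from compound 1 to compound 4 (0.82 log units; beyond the scatter), so the gain over compound 1 is not confined to the aromatic groups shown. Only 2,4-dichlorophenyl stands apart, with a 14-fold higher number from compound 2 to compound 4 (1.14 log units; beyond the scatter), which leaves compound 2 the one clear outlier in this series.

No measurement at hand accounts for any of these differences. Still open, going by these compounds, is whether unsubstituted phenyl would fall with compound 3 and compound 4, and whether fluoro or methoxy could replace the chloro groups of compound 2 with the same result.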